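The source may hold more compounds than are shown below. What is called first, only, known or untested is meant among the compounds shown, and "the series" means these compounds.

Compounds measured so far:
- Compound 1 `FC(F)(F)c1ccc(CSc2nc(Nc3ccccc3Cl)c3ccccc3n2)cc1`: > 50000 nM in a functional assay on MDA-MB-231 cells (Homo sapiens) for cytotoxicity, read by MTT assay, with a stated time of 72 h (on this read-out higher numbers stand for weaker inhibition and lower numbers for stronger inhibition), a limit of the assay and not a number.
- Compound 2 `FC(F)(F)c1ccc(CSc2nc(Nc3cccc(C(F)(F)F)c3)c3ccccc3n2)cc1`: 11100 nM.
- Compound 3 `FC(F)(F)c1ccc(CSc2nc(Nc3cccc(Br)c3)c3ccccc3n2)cc1`: 22100 nM.

Among the two numbers, compound 3 carries the higher one, but its gap to compound 2, a 2.0-fold higher number from compound 2 to compound 3 (0.30 log units; within the scatter), lies within the scatter, so the two cannot be placed in order. Compound 1 sits at the limit described by the limit of > 50000 nM in this assay, at which 1 of the 3 values shown sits.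

Compound 4 `Fc1ccc(Nc2nc(SCc3ccc(C(F)(F)F)cc3)nc3ccccc23)cc1` differs from compound 3 in one place: 4-fluorophenyl in place of 3-bromophenyl on a nitrogen on an aromatic ring.

Within the data shown here, two measured steps touch the same nitrogen substituent. Replacing 2-chlorophenyl gave an at least 4.5-fold lower number from compound 1 to compound 2 (0.65 log units; beyond the scatter) and an at least 2.2-fold lower number from compound 1 to compound 3 (0.35 log units; beyond the scatter), both read against a limit, while a 2.0-fold higher number from compound 2 to compound 3 (0.30 log units; within the scatter) shows that swapping bromo for trifluoromethyl changed little. Among the measured compounds shown here, no measured pair, however, exchanges a 3-substituted phenyl for a 4-substituted one, so the direction of the move to 4-fluorophenyl rests on no direct precedent.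

Compound 4 is therefore expected to land near compound 3, with a wide band leaning toward weaker inhibition, at 30000 nM (range 8000 nM to 60000 nM). The step of a 1.4-fold higher number from compound 3 to compound 4 (0.13 log units; within the scatter) is the estimate that follows.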

Compound 4, half-maximal inhibitory concentration: 15000 nM
For compound 4 the middle estimate is 2.0-fold (0.30 log units) above the measured one; the range from low to high includes it.
By their numbers in this assay, from the lowest: compounds 2, 4 and 3 (each within the scatter of the next). At a limit, above all of these: compound 1.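

In this assay, 4-fluorophenyl on this nitrogen cannot be told apart from either 3-substituted phenyl group, as a 1.5-fold lower number from compound 3 to compound 4 (0.17 log units; within the scatter) and a 1.4-fold higher number from compound 2 to compound 4 (0.13 log units; within the scatter) both lie within the scatter. The contrast with 2-chlorophenyl holds for this third group too, with an at least 3.3-fold lower number from compound 1 to compound 4 (0.52 log units; beyond the scatter), so compound 1 now stands apart from three compounds rather than two, though this step is read against a limit. Compound 1 alone carries that limit, which is not a number: the limit of > 50000 nM in this assay, at which 1 of the 4 values shown sits.

What the compounds shown leave open is whether the gap at compound 1 belongs to the chlorine itself or to where it sits on the phenyl ring, a question that 3-chlorophenyl and 4-chlorophenyl on the same nitrogen would address. Also open, from the compounds shown here alone, is whether any group on this nitrogen can move the number beyond the scatter of compounds 2, 3 and 4, for example an unsubstituted phenyl or a phenyl carrying an amine or a carboxylic acid.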